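The source may hold more compounds than are shown below. What is called first, only, known or untested is meant among the compounds shown, and "the series" means these compounds.

Values measured in a functional assay on A549 cells (Homo sapiens) for cytotoxicity, read by MTT assay, with a stated time of 72 h; a higher number here means a weaker inhibitor, a lower number a stronger inhibitor:
- compound 1 `Cn1ccc2c(Oc3ccc(NC(=O)c4cc5cccnc5n(-c5ccc(Br)cc5)c4=O)cc3F)ncnc21` gives 42200 nM
- compound 2 `O=C(Nc1ccc(Oc2ncnc3[nH]ccc23)c(F)c1)c1cc2cccnc2n(-c2ccccc2)c1=O` gives 45500 nM
- compound 3 `O=C(Nc1ccc(Oc2ncnc3[nH]ccc23)c(F)c1)c1cc2cccnc2n(-c2ccc(Cl)cc2)c1=O` gives 35500 nM

Still unmeasured is compound 4 `O=C(Nc1ccc(Oc2ncnc3[nH]ccc23)c(F)c1)c1cc2cccnc2n(-c2ccc(Br)cc2)c1=O`.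

At 35500 nM compound 3 sits within the scatter of both compound 1 and compound 2. Compound 4 carries bromo in place of chloro on an aromatic carbon, para to a large group. Going by the values given here, the one measured step at this place, a 1.3-fold lower number from compound 2 to compound 3 (0.11 log units; within the scatter), puts chloro in place of hydrogen and stays within the scatter. Compound 1, which also bears a 4-bromophenyl group, gives 42200 nM in this assay. The expected change is a 1.1-fold higher number from compound 3 to compound 4 (0.03 log units; within the scatter), nothing beyond the scatter and with no expected direction. For compound 4 the estimated value is 38000 nM (range 24000 nM to 60000 nM).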

Compound 4, half-maximal inhibitory concentration: 27300 nM
The estimate for compound 4 lay 1.4-fold (0.14 log units) above the measured number; the measured number falls inside the stated range.
By their numbers in this assay, from the lowest: compounds 4, 3, 1 and 2 (each within the scatter of the next).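

In this assay, 4-bromophenyl in place of 4-chlorophenyl stays within the scatter (a 1.3-fold lower number from compound 3 to compound 4 (0.11 log units; within the scatter)), as does bromo in place of hydrogen on this aromatic carbon (a 1.7-fold lower number from compound 2 to compound 4 (0.22 log units; within the scatter)). With the 4-bromophenyl group held constant, hydrogen in place of methyl on the aromatic nitrogen also stays within the scatter (a 1.5-fold lower number from compound 1 to compound 4 (0.19 log units; within the scatter)). No measurement bearing on a cause for these numbers is available. The compounds shown carry only hydrogen, chloro or bromo at this carbon, so they leave open whether an amine, a methoxy group or a carboxylic acid there would move the number beyond the scatter.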